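Shortening a Terphenyl Diol to a Biphenyl Alcohol

A few compounds are considered here, and "the series" means these few. Any claim that something is new, unique, unknown or untested is made for them only; others in the source may bear on it.

Measured compounds:
compound 1, `CC1(C)OC(=O)C2(C(=O)O1)[C@@H](c1ccc(-c3ccc(-c4ccc(O)cc4)cc3)cc1)CC(=O)C[C@H]2c1ccccc1`, 8000 nM
compound 2, `CC1(C)OC(=O)C2(C(=O)O1)[C@@H](c1ccc(O)cc1)CC(=O)C[C@H]2c1ccc(O)cc1`, > 100000 nM
compound 3, `Oc1ccc(-c2ccc(-c3cc(O)cc(O)c3)cc2)cc1`, 20000 nM

Of the compounds shown here, three have been tested in a functional assay on K562 cells (Homo sapiens) for antiproliferative activity, read by trypan blue exclusion, with a stated time of 48 h; a higher number here means a weaker inhibitor, a lower number a stronger inhibitor. Compound 1 carries the shared core of the first two compounds and a terphenyl arm, and in this assay compound 1 gives 8000 nM. Compound 2 keeps that core with two hydroxyphenyl groups, and for compound 2 the assay gives only a limit, > 100000 nM; this is the limit described by the limit of > 100000 nM in this assay, at which 1 of the 3 values shown sits. Compound 3 is the bare terphenyl diol without the core, and in this assay compound 3 gives 20000 nM, the higher of the two numbers obtained; compound 1 sits a step beyond the scatter below it.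

Compound 4, `OCc1ccc(-c2cc(O)cc(O)c2)cc1`, has not yet been measured. Compared with compound 3 it differs as follows: hydroxymethyl in place of 4-hydroxyphenyl on an aromatic carbon, para to a group of 8 heavy atoms. For the measured compounds named here, no step between measured compounds matches this change. Going by the values given here, the only related comparison is that compound 2, which also lacks the longer aryl extension, returned a limit, so a weakening beyond the scatter is expected for compound 4 rather than no change. The step expected from compound 3 to compound 4 in this assay is a 3.0-fold higher number from compound 3 to compound 4 (0.48 log units; beyond the scatter). Compound 4 is accordingly estimated at 60000 nM, within a range from 20000 nM to 200000 nM, with a real chance that only a limit is reported.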

Compound 4, half-maximal inhibitory concentration: > 80000 nM
Compound 4 gave a limit, no number (the forecaster's own chance of this, stated with the estimate: 45%); at least 1.3-fold (0.12 log units) between middle value and limit.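

Replacing 4-hydroxyphenyl with hydroxymethyl on this aromatic carbon, para to a group of 8 heavy atoms, gives an at least 4.0-fold higher number from compound 3 to compound 4 (0.60 log units; beyond the scatter) in this assay, and this is the first step among these compounds that isolates a single change. The leaving and entering groups have the same count of hydrogen-bond donors and acceptors, so that count alone does not preserve the activity of compound 3 when the six-membered aromatic ring of carbon only is lost. Compound 4 gives a limit rather than a number, so the step has a lower bound but no measured size: the limit of > 80000 nM in this assay, at which 1 of the 4 values shown sits.

One pair cannot tell whether the loss follows from removing the aromatic ring, from removing the terminal hydroxyl-bearing aryl group as a whole, or simply from having fewer heavy atoms at this position, since all of these change together. Going by these compounds, a plain phenyl or a longer chain ending in a hydroxyl at this position would help separate these readings, and how an amine or a carboxylic acid would behave there remains open.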